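The source may report more compounds than this note shows. Statements on the series, on what has been measured and on what is new or still open speak of the compounds shown alone.

In a functional assay on the whole organism with Mus musculus as the target (a lower number here means that less compound is needed, a higher number that more compound is needed for the effect), compound 1 `COc1cc2c(cc1OC)C(c1cccc(N)c1)=NN=C(S)C2` gives 18.8 umol/kg, compound 2 `COc1cc2c(cc1OC)C(c1ccc(N)cc1)=NN=C(S)C2` gives 6.3 umol/kg, and compound 3 `COc1cc2c(cc1OC)C(c1ccc(Br)cc1)=NNC(=O)C2` gives 110 umol/kg, the highest number of the three. Compound 4 `COc1cc2c(cc1OC)C(c1ccc(N)cc1)=NNC(=O)C2` departs from compound 3 by one change, amino in place of bromo on an aromatic carbon. Going by the values given here, no measured step covers this exchange directly. Among the compounds with values here, the only measured step, a 3.0-fold lower number from compound 1 to compound 2 (0.47 log units; beyond the scatter), is modest but beyond the scatter, and it concerns 4-aminophenyl in place of 3-aminophenyl rather than the loss of bromo. Its bearing is therefore indirect. Compound 4 shares its 4-aminophenyl with compound 2, which stands at 6.3 umol/kg, but the core of compound 2 differs from that of compound 3, so this value cannot simply be carried over. A clear move to a lower number is expected in this assay, probably stopping short of the full gap between compound 3 and compound 2. The expected change is a 4.4-fold lower number from compound 3 to compound 4 (0.64 log units; beyond the scatter). Compound 4 is estimated at 25 umol/kg, with an expected range from 8 umol/kg to 75 umol/kg.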

Compound 4, dose for half-maximal effect: 15 umol/kg
Estimate against measurement, compound 4: 1.7-fold (0.22 log units) above; measured number inside the range.
By their numbers in this assay, from the lowest: compound 2; then compounds 4 and 1 (each within the scatter of the next); then compound 3.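

In this assay, the exchange of bromo for amino on the aromatic carbon gives a 7.3-fold lower number from compound 3 to compound 4 (0.87 log units; beyond the scatter). This shows that the group at this place, para to a large group, strongly shapes the dose needed on the core of compound 3, whereas the earlier step concerned only where the amino group sits on the core of compound 1. Going by these compounds alone, with 4-aminophenyl held constant, compound 4 gives 15 umol/kg and compound 2 gives 6.3 umol/kg, which sets the two cores side by side for the first time, although no measurement at hand explains the step. On these data alone, whether a hydroxyl, a methoxy or a dimethylamino group at this place would behave like amino remains open. So does whether the exchange of bromo for amino would carry over to the core of compound 2.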